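The source may report more compounds than this note shows. Statements on the series, on what has been measured and on what is new or still open speak of the compounds shown alone.

Compound 1 `CCN(CC)Cc1cccc(Nc2nc3ccccc3[nH]2)c1O` is measured in an ADME assay on CHO cells (Cricetulus griseus) for inhibition, read by MTT assay; a lower number here means a stronger inhibitor, a higher number a weaker inhibitor. In this assay compound 1 gives > 50000 nM, which is a limit of the assay rather than a number. Compound 2 `CCN(CC)Cc1ccc(C)c(Nc2nc3ccccc3[nH]2)c1O` shares the core of compound 1 and carries a methyl in place of hydrogen on an aromatic carbon. In this assay compound 2 also gives > 50000 nM, again a limit of the assay. The step that the two limits leave unreadable from compound 1 to compound 2 therefore cannot be read, because of the limit of > 50000 nM in this assay, at which 2 of the 2 values shown sit.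

Compound 3 `CCN(CC)Cc1cc(C)cc(Nc2nc3ccccc3[nH]2)c1O` differs from compound 1 by methyl in place of hydrogen on an aromatic carbon. Among the measured compounds shown here, the one measured step, from compound 1 to compound 2, bears on this change in kind but gives no size. With both known values sitting at a limit, no shift beyond the scatter is expected in this assay, and it is expected that compound 3 will most likely again show only a limit. For compound 3 the expected value in this assay is 100000 nM, estimated to fall between 40000 nM and 300000 nM, which means an expected step that the limit leaves unreadable from compound 1 to compound 3.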

Compound 3, half-maximal inhibitory concentration: > 50000 nM
Compound 3 gave a limit, no number (the forecaster's own chance of this, stated with the estimate: 85%); the middle value does not contradict the limit.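

In this assay no new step can be read from compound 1 to compound 3, because both compounds show only a limit of the assay: the limit of > 50000 nM in this assay, at which 3 of the 3 values shown sit.

The compounds shown leave open whether a methyl in place of hydrogen on an aromatic carbon changes inhibition at all.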